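From phenyl to (furan-2-yl)methyl on compound 3

This account rests on a few compounds, and the source may have more. Where it says the series, first, only, none or still open, it means among the compounds named here.

Of the compounds shown here, three have been measured in a functional assay on the whole organism with Mus musculus as the target; on this read-out lower numbers stand for an effect already at smaller amounts and higher numbers for an effect only at larger amounts of compound. Compound 1 `CNC(=O)[C@@H](CC(C)C)NCc1ccc(OCc2ccccc2)cc1` gives 192 mg/kg, compound 2 `C[C@H](Nc1cccc(OCc2ccccc2)c1)C(N)=O` gives 79.7 mg/kg, and compound 3 `C[C@@H](NCc1ccc(Oc2ccccc2)cc1)C(N)=O` gives 64 mg/kg. Compound 3 and compound 2 agree within the scatter, while compound 1 has the higher number than compound 3, beyond the scatter. Compound 4 `C[C@@H](NCc1ccc(OCc2ccco2)cc1)C(N)=O` carries (furan-2-yl)methyl in place of phenyl on an oxygen on an aromatic ring. For the measured compounds named here, no measured pair isolates a change of this kind, so the expectation in this assay is no step beyond the scatter. The expected step is a 1.3-fold lower number from compound 3 to compound 4 (0.11 log units; within the scatter). Compound 4 is estimated at 50 mg/kg, with an expected range of 18 mg/kg to 130 mg/kg.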

Compound 4, dose for half-maximal effect: 116 mg/kg
Estimate against measurement, compound 4: 2.3-fold (0.37 log units) below, and the stated range covers the measured number.
By their numbers in this assay, from the lowest: compounds 3, 2, 4 and 1 (each within the scatter of the next, the first and the last beyond it).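

For the compounds shown here, this is the first pair in this assay that differs in one place, and the exchange gives a 1.8-fold higher number from compound 3 to compound 4 (0.26 log units; within the scatter) for the group on an oxygen on an aromatic ring. At this position, a five-membered aromatic ring with an oxygen, held on a methyl link, can thus stand in place of phenyl without a step beyond the scatter. Nothing measured here explains the result. Still open, on these data alone, is whether (thiophen-2-yl)methyl, or a group carrying an amine or a carboxylic acid, would also stay within the scatter at this position.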